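Same atoms, joined differently, in compound 4

The source may report more compounds than this note shows. Statements on the series, on what has been measured and on what is new or still open speak of the compounds shown alone.

In a functional assay on the whole organism with Mus musculus as the target (a lower number here means that less compound is needed, a higher number that more compound is needed for the effect), compound 1 (`CC[C@@H](C(=O)N(C)OC)N1CCCC1=O`) gives 1000 umol/kg, compound 2 (`CC[C@@H](C(=O)NOC)N1CCCC1=O`) gives 1000 umol/kg and compound 3 (`CC[C@@H](C(=O)NN)N1CCCC1=O`) gives 1000 umol/kg. Compound 3 thus stands level with compounds 1 and 2. Compound 4 (`CC[C@@H](C(=N)NO)N1CCCC1=O`) is still unmeasured. It has the same atoms as compound 3, joined differently: a group of 4 heavy atoms (1 carbon, 2 nitrogen, 1 oxygen; no ring) in place of a group of 4 heavy atoms (1 carbon, 2 nitrogen, 1 oxygen; no ring), on a saturated chain carbon bound to an amide-type nitrogen in a ring and a saturated chain carbon. The change lies on a saturated chain carbon bound to an amide-type nitrogen in a ring and a saturated chain carbon. Within the data shown here, three measured steps bear on it, all changes within the group on that carbon: no change at the digits printed from compound 1 to compound 2 (within the scatter), no change at the digits printed from compound 1 to compound 3 (within the scatter) and no change at the digits printed from compound 2 to compound 3 (within the scatter). None of them goes beyond the scatter. Among the measured compounds shown here, the group entering in compound 4 has no measured precedent, so these steps are only a weak guide. No step beyond the scatter is expected in this assay. The expected step is no change at the digits printed from compound 3 to compound 4 (within the scatter). For compound 4 the estimated value is 1000 umol/kg, with an estimated range from 400 umol/kg to 2000 umol/kg.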

Compound 4, dose for half-maximal effect: 1000 umol/kg
Estimate against measurement, compound 4: no gap at the digits printed; measured number inside the range.
By their numbers in this assay, from the lowest: compounds 1, 2, 3 and 4 (each within the scatter of the next).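

In this assay the change of connectivity on the saturated chain carbon bound to an amide-type nitrogen in a ring and a saturated chain carbon gives no change at the digits printed from compound 3 to compound 4 (within the scatter) and so does not separate the two isomeric groups. Among these compounds, compound 4 is the first in this set without a carbonyl in the group at this position, and it carries 3 hydrogen-bond donors in place of 2 hydrogen-bond donors, so neither difference moves the read-out beyond the scatter here. No measured evidence accounts for this result.

All four compounds share one value, so the series does not yet show any group at this position moving the read-out. As far as these compounds go, whether a carboxylic acid, a primary amide or a longer chain on that carbon would depart from this value remains open.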